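Cyclopropane amide series: thiazole in place of cyanophenyl

The compounds below may be only part of what the source reports. "The series", "measured", "known", "first", "only" and "open" are said of these compounds alone.

Measured so far:
compound 1 `CC[C@H](C)[C@@H](CN(C(=O)[C@@H]1C[C@H]1c1ccccc1)c1ccc(-c2ccccc2)cc1)NC(C)=O` — 5.8 nM
compound 2 `CC[C@H](C)[C@H](N)CN(C(=O)[C@@H]1C[C@H]1c1cccc(C#N)c1)c1ccc(-c2ccccc2)cc1` — 1600 nM

Of the compounds shown here, two have been measured in a functional assay for agonist activity at G protein-coupled receptor 88 (Homo sapiens), read by HTRF and cAMP accumulation; a higher number here means that more compound is needed for the effect, a lower number that less compound is needed. Compound 1 gives 5.8 nM and compound 2 gives 1600 nM. Within the data shown here, compound 2 thus stands highest of the two numbers, and its only neighbour, compound 1, sits at a far lower value, well beyond the scatter. Compound 1 and compound 2 differ in more than one place, so no single step can be read from that pair.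

Compound 3 `CC[C@H](C)[C@H](N)CN(C(=O)[C@@H]1C[C@H]1c1nc(C)c(C)s1)c1ccc(-c2ccccc2)cc1` is not yet measured. It follows from compound 2 by one change: 4,5-dimethyl-1,3-thiazol-2-yl in place of 3-cyanophenyl on a saturated ring carbon. Among the measured compounds shown here, no measured pair shows this change, and the two values at hand say nothing about how a 4,5-dimethyl-1,3-thiazol-2-yl in place of 3-cyanophenyl on a saturated ring carbon behaves. The expected step is therefore small, a 1.2-fold lower number from compound 2 to compound 3 (0.09 log units; within the scatter), with no direction claimed beyond the scatter. Compound 3 is expected to give about 1300 nM, within a range from 300 nM to 6000 nM.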

Compound 3, half-maximal effective concentration: 3600 nM
Compound 3: the middle estimate sits 2.8-fold (0.44 log units) below what was measured; the measured number falls inside the stated range.
By their numbers in this assay, from the lowest: compound 1; then compound 2; then compound 3.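

In this assay, the swap of 3-cyanophenyl for 4,5-dimethyl-1,3-thiazol-2-yl on a saturated ring carbon of the three-membered ring gives a 2.3-fold higher number from compound 2 to compound 3 (0.35 log units; beyond the scatter). Among these compounds, this is the first single-place step at this position, and it is modest: a five-membered aromatic ring with 2 hetero atoms, and no nitrile, still gives a measurable number here. No measured data bear on what lies behind this step.

The compounds shown do not separate the contribution of the two methyl groups from that of the thiazole ring, which an unsubstituted 1,3-thiazol-2-yl would address. As far as these compounds go, whether a pyridin-3-yl at this position would give a lower number than either 3-cyanophenyl or 4,5-dimethyl-1,3-thiazol-2-yl also remains open.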